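This account rests on a few compounds, and the source may have more. Where it says the series, first, only, none or still open, it means among the compounds named here.

Of the compounds shown here, three have been measured in an assay on membranes from striatum (strain Sprague-Dawley) for displacement of a labelled ligand from sodium-dependent dopamine transporter (Rattus norvegicus), read by scintillation counting, with a stated time of 120 min; a lower number here means a stronger inhibitor, a higher number a weaker inhibitor. Within the data shown here, compound 1 `[O-][S+](CCNC1CCN(Cc2ccc(F)cc2)CC1)C(c1ccc(F)cc1)c1ccc(F)cc1` gives 50.6 nM, and compound 2 `[O-][S+](CCNC1CCN(CC(O)Cc2ccccc2)CC1)C(c1ccc(F)cc1)c1ccc(F)cc1` gives 91.8 nM; the single change between them, a 1.8-fold higher number from compound 1 to compound 2 (0.26 log units; within the scatter), stays within the scatter. Compound 3 `O=C(c1ccc(F)cc1)N1CCC(NCCSC(c2ccc(F)cc2)c2ccc(F)cc2)CC1` gives 7.04 nM, the lowest of the three numbers, beyond the scatter from compound 1 and from compound 2. Compound 4 `O=C(c1ccccc1F)N1CCC(NCCSC(c2ccc(F)cc2)c2ccc(F)cc2)CC1` differs from compound 3 by 2-fluorophenyl in place of 4-fluorophenyl on a carbonyl carbon. No measured step touches this part of the structure; the only step shown concerns a different part of the shared core and stayed within the scatter. On that basis the step from compound 3 to compound 4 in this assay is expected to be small, a 1.3-fold higher number from compound 3 to compound 4 (0.11 log units; within the scatter). Compound 4 is therefore estimated at 9 nM, in the range 4 nM to 25 nM.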

Compound 4, inhibition constant: 46.1 nM
Estimate against measurement, compound 4: 5.1-fold (0.71 log units) below; measured number above the stated range.
By their numbers in this assay, from the lowest: compound 3; then compounds 4, 1 and 2 (each within the scatter of the next).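

In this assay, 2-fluorophenyl in place of 4-fluorophenyl on a carbonyl carbon gives a 6.5-fold higher number from compound 3 to compound 4 (0.82 log units; beyond the scatter). Among these compounds, this place therefore responds to a change that keeps the same atoms joined differently, which the only earlier step, in a different part of the shared core and within the scatter, could not show. Nothing measured here explains the step. The compounds shown leave open how an unsubstituted phenyl or a pyridine ring on this carbonyl carbon would compare with compound 3 and compound 4.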